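Shifting the Chlorine on the Benzyl Group

The source may report more compounds than this note shows. Statements on the series, on what has been measured and on what is new or still open speak of the compounds shown alone.

Compound 1 `CC1=C(C(=O)Nc2ccc([N+](=O)[O-])cc2)C(c2ccc(Br)cc2)N=C(SCc2ccc(Cl)cc2)N1` gives 19.1% in a functional assay on the whole organism (artery, strain albino) with Rattus norvegicus as the target, with a stated time of 180 min, at a dose of 10 mg/kg by the oral route; a lower number here means less inhibition, a higher number more inhibition at the dose given (going by the name of the read-out).
Compound 2 `CC1=C(C(=O)Nc2ccc([N+](=O)[O-])cc2)C(c2cccc([N+](=O)[O-])c2)N=C(SCc2cccc(Cl)c2)N1` gives 14.9% in this assay.

Among the measured compounds shown here, of the two numbers measured so far, the value of compound 2 is the lowest, with compound 1 nearest; the gap between them lies within the scatter, so the two compounds are not told apart by this read-out. Compound 3 `CC1=C(C(=O)Nc2ccc([N+](=O)[O-])cc2)C(c2cccc([N+](=O)[O-])c2)N=C(SCc2ccc(Cl)cc2)N1` differs from compound 2 in one place: 4-chlorophenyl in place of 3-chlorophenyl on a saturated chain carbon bound to a sulfur. For the measured compounds named here, no step between measured compounds that differ in a single place is available, and compounds 1 and 2 differ from each other in more than one place, so their two values show only that both fall in the same low region of this assay. Exchanging 3-chlorophenyl for 4-chlorophenyl on a saturated chain carbon bound to a sulfur is expected to move this assay little, in no clear direction, and not beyond the scatter. Compound 3 is therefore expected to give 17%, within 8% to 27%. The step from compound 2 to compound 3 is estimated as a number 2.1 percentage points higher from compound 2 to compound 3 (within the scatter).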

Compound 3, a percentage reported as inhibition, in the whole organism at one dose (the size of the read-out at that dose, not a potency): 14.9%
Estimate against measurement, compound 3: 2.1 percentage points above, within the range that was stated.
By their numbers in this assay, from the lowest: compounds 2, 3 and 1 (each within the scatter of the next).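

Among the compounds shown here, exchanging 3-chlorophenyl for 4-chlorophenyl on a saturated chain carbon bound to a sulfur gives no change at the digits printed from compound 2 to compound 3 (within the scatter) in this assay, the first reading of a change made at this position alone, and the read-out does not tell the 3-chlorobenzyl and 4-chlorobenzyl compounds apart. With the 4-chlorobenzyl group held fixed, the exchange of 4-bromophenyl for 3-nitrophenyl on a saturated ring carbon gives a number 4.2 percentage points lower from compound 1 to compound 3 (within the scatter) and, like the chlorine shift, is not resolved by this read-out. No separate measurement bears on these results, so they can be reported but not explained.

The compounds shown leave open whether any other group on the benzyl ring, such as an amine or a carboxylic acid in place of the chlorine, would give a value that stands clear of these three. On these data alone, it also remains open whether a longer chain in place of the benzyl group on the sulfur would change the read-out, since only chlorobenzyl groups appear at this position.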